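From hydrazide to primary amide on a shared core

The source may report more compounds than this note shows. Statements on the series, on what has been measured and on what is new or still open speak of the compounds shown alone.

Three compounds with one shared core were measured in an ADME assay on liver (Homo sapiens) for metabolic stability, read by LC-MS, using S9 fraction and NADPH, with a stated time of 45 min, tested at 1 uM; a higher number here means that the compound lasts longer, a lower number that the compound disappears faster. Compound 1 `COCCOC(=O)c1cc(N)c(Nc2ccc(C#N)cc2)cc1Oc1c(C)cc(/C=C/C#N)cc1C` gives 0.158 h. Compound 2 `CCNC(=O)c1cc(N)c(Nc2ccc(C#N)cc2)cc1Oc1c(C)cc(/C=C/C#N)cc1C` gives 1.02 h, and compound 3 `Cc1cc(/C=C/C#N)cc(C)c1Oc1cc(Nc2ccc(C#N)cc2)c(N)cc1C(=O)NN` gives 0.65 h, so compound 3 stands second of the three, close to compound 2 and well above compound 1. The steps of a 6.5-fold higher number from compound 1 to compound 2 (0.81 log units; beyond the scatter) and a 4.1-fold higher number from compound 1 to compound 3 (0.61 log units; beyond the scatter) were both modest, whereas the step of a 1.6-fold lower number from compound 2 to compound 3 (0.20 log units; within the scatter) lay within the scatter. Compound 4 `Cc1cc(/C=C/C#N)cc(C)c1Oc1cc(Nc2ccc(C#N)cc2)c(N)cc1C(N)=O` differs from compound 3 by hydrogen in place of amino on an amide-type nitrogen. Among the compounds with values here, the one earlier step touching that same nitrogen showed nothing beyond the scatter, so the expected step is a 1.2-fold higher number from compound 3 to compound 4 (0.09 log units; within the scatter). Compound 4 is therefore estimated at 0.8 h, within a range of 0.35 h to 1.8 h.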

Compound 4, half-life: 1.8 h
Compound 4: the middle estimate sits 2.3-fold (0.35 log units) below what was measured; measured number inside the range.
By their numbers in this assay, from the lowest: compound 1; then compounds 3, 2 and 4 (each within the scatter of the next, the first and the last beyond it).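

In this assay hydrogen in place of amino on the amide-type nitrogen gives a 2.8-fold higher number from compound 3 to compound 4 (0.44 log units; beyond the scatter) and so, unlike the earlier step at that nitrogen, a change there moves the half-life beyond the scatter. Hydrogen in place of ethyl on the same nitrogen gives a 1.8-fold higher number from compound 2 to compound 4 (0.25 log units; within the scatter) and stays within it, while amino in place of 2-methoxyethoxy on the carbonyl carbon gives an 11-fold higher number from compound 1 to compound 4 (1.06 log units; beyond the scatter) and is the only large step shown. No measurement shown accounts for these steps. From the compounds shown here alone, how a methyl group or a longer propyl chain on that nitrogen would stand remains open, as does a carboxylic acid on the shared core in place of the amide.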